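Nitrophenyl Ether Thiourea: Cytotoxicity Expected Near the Limit

The compounds below may be only part of what the source reports. "The series", "measured", "known", "first", "only" and "open" are said of these compounds alone.

Compound 1, `O=S(=O)(NCCNC(=S)Nc1cc(C(F)(F)F)cc(C(F)(F)F)c1)c1ccc(-c2ccccc2OCc2ccccc2)s1`: in an ADME assay on HEK-293T cells (Homo sapiens) for cytotoxicity, read by CCK-8 assay, with a stated time of 48 h (on this read-out higher numbers stand for weaker inhibition and lower numbers for stronger inhibition), compound 1 gives 8500 nM.
Compound 2, `O=C(NCCNS(=O)(=O)c1ccc(-c2ccccc2Oc2ccc([N+](=O)[O-])c([N+](=O)[O-])c2)s1)Nc1cc(C(F)(F)F)cc(C(F)(F)F)c1`: compound 2 reaches only a limit of this assay, > 50000 nM.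
Compound 3, `O=S(=O)(NCCNC(=S)Nc1cc(C(F)(F)F)cc(C(F)(F)F)c1)c1ccc(-c2ccccc2O[C@H]2CC[C@@H](O)CC2)s1`: compound 3 likewise reaches only a limit, > 20000 nM.

Compound 3 therefore stands at the weak end of everything measured here: its value is the limit of > 20000 nM in this assay, at which 1 of the 3 values shown sits, a limit and not a number. Within the data shown here, the single step leading to it, an at least 2.3-fold higher number from compound 1 to compound 3 (0.37 log units; beyond the scatter), pushed the reading out of the measurable range. Compound 4, `O=[N+]([O-])c1ccc(Oc2ccccc2-c2ccc(S(=O)(=O)NCCNC(=S)Nc3cc(C(F)(F)F)cc(C(F)(F)F)c3)s2)cc1`, is not yet measured. It differs from compound 3 in one place: 4-nitrophenyl in place of 4-hydroxycyclohexyl on an oxygen on an aromatic ring. Among the measured compounds shown here, no measured step exchanges these two groups, so the only guidance is that changes at this oxygen have moved the number beyond the scatter once, and that compound 2, which also carries a nitro-bearing ring at this position, sits at a limit. A step that the limit leaves unreadable from compound 3 to compound 4 is expected, that is, no clear movement beyond the scatter. Compound 4 is estimated at 30000 nM, with a range from 12000 nM to 80000 nM, most likely reported again as a limit.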

Compound 4, half-maximal inhibitory concentration: 6000 nM
For compound 4 the middle estimate is 5.0-fold (0.70 log units) above the measured one; measured number outside the range, below it.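

Replacing 4-hydroxycyclohexyl with 4-nitrophenyl on this oxygen brings the reading back into the measurable range of this assay, with an at least 3.3-fold lower number from compound 3 to compound 4 (0.52 log units; beyond the scatter); here a lower number means stronger inhibition. From the compounds shown here alone, the true size of this step is unknown, as the reading for compound 3 is a limit and not a number: the limit of > 20000 nM in this assay, at which 1 of the 4 values shown sits. Benzyl and 4-nitrophenyl cannot be told apart at this position, with a 1.4-fold lower number from compound 1 to compound 4 (0.15 log units; within the scatter), so among compounds 1, 3 and 4 only the 4-hydroxycyclohexyl compound reaches a limit.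

Compound 2 also carries a nitro-bearing ring yet reaches a limit, which goes against any simple rule about aromatic groups here, but it differs from compound 4 in more than one place. Going by these compounds, whether the nitro group matters at all remains open, and plain phenyl or 4-aminophenyl on this oxygen would help to test it.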